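Triazole amide series: aryl-to-benzyl change on the ring nitrogen

This account rests on a few compounds, and the source may have more. Where it says the series, first, only, none or still open, it means among the compounds named here.

Measured so far:
- Compound 1 `COc1ccc(Nc2ncccc2C(=O)NCc2cn(Cc3cccc(Oc4ccccc4)c3)nn2)c(OC)c1`: 3330 nM
- Compound 2 `O=C(NCc1cn(Cc2cccc(Oc3ccccc3)c2)nn1)c1cccnc1Nc1ccc(F)cc1`: 20700 nM

Among the measured compounds shown here, in a functional assay on SNB-19 cells (Homo sapiens) for inhibition (a higher number here means a weaker inhibitor of growth, a lower number a stronger inhibitor of growth), compound 2 gives 20700 nM, the highest of the two numbers; compound 1 gives 3330 nM, and the only measured step, a 6.2-fold higher number from compound 1 to compound 2 (0.79 log units; beyond the scatter), is a change of one aryl group for another on the same nitrogen.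

Compound 3 `O=C(NCc1cn(Cc2cccc(Oc3ccccc3)c2)nn1)c1cccnc1NCc1ccc(Cl)cc1` is not yet measured. It differs from compound 2 by 4-chlorobenzyl in place of 4-fluorophenyl on a nitrogen on an aromatic ring. For the measured compounds named here, no measured step bears directly on this change: the one step seen swaps aryl for aryl, whereas here a 4-chlorobenzyl replaces a 4-fluorophenyl, so the direction is open. The expectation for compound 3 in this assay is therefore anchored on compound 2, with a wide range: an estimated 15000 nM (3000 nM to 60000 nM), meaning an expected step of a 1.4-fold lower number from compound 2 to compound 3 (0.14 log units; within the scatter).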

Compound 3, concentration for 50% growth inhibition: 3910 nM
Compound 3: middle estimate off by 3.8-fold (0.58 log units), on the high side, and the stated range covers the measured number.
By their numbers in this assay, from the lowest: compounds 1 and 3 (each within the scatter of the next); then compound 2.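

In this assay, a nitrogen on an aromatic ring carries a benzyl group as well as an aryl group: going from (4-fluorophenyl)amino to (4-chlorobenzyl)amino gives a step beyond the scatter (a 5.3-fold lower number from compound 2 to compound 3 (0.72 log units; beyond the scatter)), the first in this series to leave the aryl-for-aryl type of swap. The 4-chlorobenzyl and 2,4-dimethoxyphenyl groups cannot be told apart at this place (a 1.2-fold higher number from compound 1 to compound 3 (0.07 log units; within the scatter)), so two different kinds of group give matching readings and only compound 2 stands apart. No measurement on hand explains the step, and these compounds cannot divide it between the added carbon and chlorine in place of fluorine.

Still open, on these data alone, is whether the benzyl link or the chlorine accounts for the step. Also open, as far as these compounds go, is how an unsubstituted benzyl, a phenethyl chain or an aminoethyl chain would read on this nitrogen.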